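The compounds below may be only part of what the source reports. "The series", "measured", "known", "first", "only" and "open" are said of these compounds alone.

Compound 1: `CC(C)=CCC/C(C)=C/COc1ccc(C2SCC(=O)N2Cc2ccccc2)cc1`, in a toxicity assay on HeLa cells (Homo sapiens) for cytotoxicity (a higher number here means that more compound is tolerated, a lower number that less compound is tolerated), compound 1 gives > 100000 nM.
Compound 2: `CC(C)=CCCC(C)CCOc1ccc(C2SCC(=O)N2Cc2ccccc2)cc1`, in this assay compound 2 gives "nd" (no result reported).

Compound 1 and compound 2 share the same core and differ in the chain bound to it. For compound 1 the reported value is a limit of the assay rather than a number: the limit of > 100000 nM in this assay, at which 1 of the 2 values shown sits. Compound 2 stands nowhere on the numbers shown, since no value at all was reported for it in this assay.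

The step from compound 2 to compound 3 alters the chain: a group of 9 heavy atoms (9 carbon; one four-membered non-aromatic ring of carbon only, one six-membered non-aromatic ring of carbon only) in place of a group of 8 heavy atoms (8 carbon; no ring), on a saturated chain carbon, two bonds along the chain from an oxygen on an aromatic ring. Compound 3 is `CC1(C)C2CC=C(CCOc3ccc(C4SCC(=O)N4Cc4ccccc4)cc3)C1C2`. Among the measured compounds shown here, no measured step between these compounds exists to guide this change, so the expectation rests on compound 1 alone, whose result in this assay is a limit. With only that anchor, no step beyond the scatter is expected in either direction from the change of chain. Compound 3 is expected to give about 100000 nM in this assay, most likely again reported as a limit, within a range from 30000 nM to 300000 nM.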

Compound 3, half-maximal cytotoxic concentration: > 100000 nM
Compound 3 ended at the assay's limit (the forecaster's own chance of this, stated with the estimate: 80%); the middle value sits exactly at the limit.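

Compound 1 and compound 3 both end at a limit of this assay rather than at a number, so no step between them can be read: the limit of > 100000 nM in this assay, at which 2 of the 3 values shown sit.

The compounds shown leave open what concentration of compound 1 or compound 3 would harm the cells, and how compound 2 compares with either of them.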